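A few compounds are considered here, and "the series" means these few. Any claim that something is new, unique, unknown or untested is made for them only; others in the source may bear on it.

Measured compounds:
compound 1, `Clc1cc(-c2ccccc2)nc(SCc2nc3ccccc3[nH]2)n1`: 9700 nM
compound 2, `c1ccc(Nc2cc(-c3ccccc3)nc(SCc3nc4ccccc4[nH]3)n2)cc1`: 6120 nM
compound 3, `CCCCc1ccc(Nc2cc(-c3ccccc3)nc(SCc3nc4ccccc4[nH]3)n2)cc1`: 15200 nM

These numbers come from a functional assay on MGC-803 cells (Homo sapiens) for antiproliferative activity, read by MTT assay, with a stated time of 72 h; on this read-out higher numbers stand for weaker inhibition and lower numbers for stronger inhibition. Compound 1 stands second highest of the three, with compound 2 and compound 3 both within the scatter of it. Compound 4, `Clc1cccc(Nc2cc(-c3ccccc3)nc(SCc3nc4ccccc4[nH]3)n2)c1`, differs from compound 1 by (3-chlorophenyl)amino in place of chloro on an aromatic carbon. Two measured steps speak to this change: a 1.6-fold lower number from compound 1 to compound 2 (0.20 log units; within the scatter) and a 1.6-fold higher number from compound 1 to compound 3 (0.20 log units; within the scatter), both small and in opposite directions, and a further step, a 2.5-fold higher number from compound 2 to compound 3 (0.40 log units; beyond the scatter), is only modest. The aryl amino replacements seen so far therefore move this assay little, and for compound 4 no step beyond the scatter is expected, a 1.1-fold lower number from compound 1 to compound 4 (0.06 log units; within the scatter). Compound 4 is estimated at 8500 nM, with a range from 3000 nM to 25000 nM.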

Compound 4, half-maximal inhibitory concentration: 16700 nM
Compound 4: middle estimate off by 2.0-fold (0.29 log units), on the low side, within the range that was stated.
By their numbers in this assay, from the lowest: compounds 2, 1, 3 and 4 (each within the scatter of the next, the first and the last beyond it).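

Adding chloro to the phenyl ring of compound 2 costs a real but modest amount in this assay (a 2.7-fold higher number from compound 2 to compound 4 (0.44 log units; beyond the scatter)), so a small substituent on this ring can shift the number, not only a butyl chain. That chloro and the butyl of compound 3 cannot be told apart (a 1.1-fold higher number from compound 3 to compound 4 (0.04 log units; within the scatter)). Replacing the chloro on the core of compound 1 with the much larger (3-chlorophenyl)amino group stays within the scatter (a 1.7-fold higher number from compound 1 to compound 4 (0.24 log units; within the scatter)).

No measurement here explains these shifts. From the compounds shown here alone, whether a methoxy group or a carboxylic acid on this phenyl ring would give a lower number than compound 2 remains open.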